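The source may hold more compounds than are shown below. What is called first, only, known or untested is meant among the compounds shown, and "the series" means these compounds.

Compound 2 `O=c1cc(-n2cc(COc3ccccc3)nn2)c2cc(Br)ccc2o1` carries a phenoxymethyl group on the shared core. In a functional assay on SW480 cells (Homo sapiens) for antiproliferative activity, read by MTT assay, with a stated time of 48 h (on this read-out higher numbers stand for weaker inhibition and lower numbers for stronger inhibition), compound 2 gives 4990 nM, the lowest of the three numbers recorded so far. Among the measured compounds shown here, compound 1 `O=c1cc(-n2cc(-c3ccccc3)nn2)c2cc(Br)ccc2o1`, which bears a phenyl group instead, gives 6660 nM in this assay; the two values lie within the scatter of one another, and the only single-point step, a 1.3-fold lower number from compound 1 to compound 2 (0.13 log units; within the scatter), is accordingly small. For the measured compounds named here, compound 3 `O=c1cc(-n2cc(COc3ccnc4ccc(Br)cc34)nn2)c2cc(Br)ccc2o1` gives 17000 nM in this assay, a number that sits beyond the scatter above that of compound 2, but this pair differs in more than one place and no single step is counted for it.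

Compound 4 `O=c1cc(-n2cc(COc3ccccc3O)nn2)c2cc(Br)ccc2o1` differs from compound 2 by hydroxy in place of hydrogen on an aromatic carbon. Going by the values given here, no measured step adds a hydroxy group, so none bears directly on the change; the one step available, a 1.3-fold lower number from compound 1 to compound 2 (0.13 log units; within the scatter), exchanged the whole aromatic substituent and still stayed within the scatter. Among the compounds with values here, with no closer precedent, the step in this assay is expected to be small, a 1.0-fold higher number from compound 2 to compound 4 (0.00 log units; within the scatter), remaining within the scatter. Compound 4 is therefore expected to give 5000 nM in this assay, with a range from 2500 nM to 10000 nM.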

Compound 4, half-maximal inhibitory concentration: 19100 nM
Estimate against measurement, compound 4: 3.8-fold (0.58 log units) below, and the stated range ends below it.
By their numbers in this assay, from the lowest: compounds 2 and 1 (each within the scatter of the next); then compounds 3 and 4 (each within the scatter of the next).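

Hydroxy in place of hydrogen on the phenoxy ring, ortho to a large group, gives a 3.8-fold higher number from compound 2 to compound 4 (0.58 log units; beyond the scatter) in this assay, so inhibition is weaker and this is the first single-place step in the series to pass beyond the scatter. The earlier step, a 1.3-fold lower number from compound 1 to compound 2 (0.13 log units; within the scatter), exchanged the whole aromatic substituent without leaving the scatter, and so gave no sign that the series was sensitive to a change at this aromatic ring; the new step shows that one added oxygen atom at this place is enough to move the number, and that the change is not tolerated as the earlier step might have suggested. No measurement on hand accounts for this loss, and the reason for it remains open.

The compounds shown cannot say whether the step belongs to the hydroxy group itself or to any substituent at this place, a question that a methoxy group, a fluorine atom or an amine at the same carbon would address. They also leave open whether the same change, phenyl to 2-hydroxyphenyl, would carry over to compound 1, where the ring sits directly on the shared core's triazole-bearing side chain.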